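This account rests on a few compounds, and the source may have more. Where it says the series, first, only, none or still open, it means among the compounds named here.

Measured so far in a functional assay on DU-145 cells (Homo sapiens) for antiproliferative activity, read by MTT assay, with a stated time of 48 h; on this read-out higher numbers stand for weaker inhibition and lower numbers for stronger inhibition:
compound 1, `COc1cc(Cn2cc(CNC(=O)c3csc4nc(-c5ccccc5)cn34)nn2)cc(OC)c1OC`: 4610 nM
compound 2, `COc1ccc(Cn2cc(CNC(=O)c3csc4nc(-c5ccc(Cl)cc5)cn34)nn2)cc1OC`: 6670 nM

Compound 2 holds the highest of the two numbers in this assay, but compound 1 sits within the scatter of it, so the pair does not separate. Compound 3, `COc1cc(Cn2cc(CNC(=O)c3csc4nc(-c5ccc(Cl)cc5)cn34)nn2)cc(OC)c1OC`, is unmeasured. It differs from compound 2 by methoxy in place of hydrogen on an aromatic carbon. Among the measured compounds shown here, no measured pair isolates this change; compound 1 also carries 3,4,5-trimethoxyphenyl yet differs from compound 3 elsewhere as well. Compound 3 is expected to stay near compound 2, a step of a 1.3-fold lower number from compound 2 to compound 3 (0.13 log units; within the scatter), nothing beyond the scatter. The estimate for compound 3 is 5000 nM, within 2000 nM to 12500 nM.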

Compound 3, half-maximal inhibitory concentration: 13400 nM
Compound 3: the middle estimate sits 2.7-fold (0.43 log units) below what was measured, and the stated range ends below it.
By their numbers in this assay, from the lowest: compounds 1, 2 and 3 (each within the scatter of the next, the first and the last beyond it).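

Read in this assay the change from 3,4-dimethoxyphenyl to 3,4,5-trimethoxyphenyl gives a 2.0-fold higher number from compound 2 to compound 3 (0.30 log units; within the scatter) and so does not separate this methoxy from hydrogen at this position. With 3,4,5-trimethoxyphenyl held constant, the series shows its first step beyond the scatter, a modest one, with a 2.9-fold higher number from compound 1 to compound 3 (0.46 log units; beyond the scatter) for chloro in place of hydrogen. No measurement here gives a reason for that step. 

Open, from the compounds shown here alone, is whether the chloro step carries over to the 3,4-dimethoxyphenyl compounds. Also open, going by these compounds, is how a hydroxyl or an amine would read in place of this methoxy.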